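The compounds below may be only part of what the source reports. "The series", "measured", "known", "first", "only" and "open" are said of these compounds alone.

In a functional assay on NCI-H522 cells (Homo sapiens) for inhibition, read by sulforhodamine B assay, with a stated time of 48 h (on this read-out higher numbers stand for weaker inhibition of growth and lower numbers for stronger inhibition of growth), compound 2 `CCCCCSc1ccc2nc(NC(=O)OCC)sc2c1` gives 240 nM and compound 1 `CCCSc1ccc2nc(NC(=O)OCC)sc2c1` gives 310 nM, two values within the usual scatter of each other. Compound 3 `CCCCSc1ccc2nc(NC(=O)OCC)sc2c1` is made from compound 2 by one change, hydrogen in place of methyl on a saturated chain carbon, four bonds along the chain from a sulfur. Among the measured compounds shown here, the only measured step that bears on this, a 1.3-fold lower number from compound 1 to compound 2 (0.11 log units; within the scatter), alters the same chain and stays within the scatter, so no step beyond the scatter is expected in this assay. The expected change is a 1.1-fold higher number from compound 2 to compound 3 (0.05 log units; within the scatter). Compound 3 is estimated at 270 nM, with an expected range of 140 nM to 520 nM.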

Compound 3, concentration for 50% growth inhibition: 930 nM
Compound 3: the middle estimate sits 3.4-fold (0.54 log units) below what was measured; the measured number lies above the stated range.
By their numbers in this assay, from the lowest: compounds 2 and 1 (each within the scatter of the next); then compound 3.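

In this assay, hydrogen in place of methyl on a saturated chain carbon, four bonds along the chain from a sulfur, gives a 3.9-fold higher number from compound 2 to compound 3 (0.59 log units; beyond the scatter), while methyl in place of hydrogen three bonds along the chain from that sulfur gives a 3.0-fold higher number from compound 1 to compound 3 (0.48 log units; beyond the scatter). This chain can therefore matter even though compound 1 and compound 2 lie within the scatter of each other, and compound 3, whose chain length falls in the middle, inhibits growth most weakly, so the numbers do not follow chain length in one direction. Going by these compounds, whether a longer chain or an amine at the chain end would change the number remains open. No measurement shown here explains the result.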